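The source may hold more compounds than are shown below. What is called first, only, known or untested is meant among the compounds shown, and "the series" means these compounds.

Compound 1 `C=C1CC(Cn2cc(C)c(=O)[nH]c2=O)(c2ccc(-c3ccccc3)cc2)OC1=O` gives 13200 nM in a functional assay on U-251 cells (Homo sapiens) for inhibition; on this read-out lower numbers stand for stronger inhibition of growth and higher numbers for weaker inhibition of growth.
Compound 2 `C=C1CC(Cn2cc(C)c(=O)[nH]c2=O)(c2ccc(F)cc2)OC1=O` gives 11500 nM.
Compound 3 `C=C1CC(Cn2ccc(=O)[nH]c2=O)(c2ccc(-c3ccccc3)cc2)OC1=O` gives 10000 nM.

The number for compound 2 lies among three that all fall within the usual scatter of one another, so none of them can be called stronger or weaker than the others; the closest is compound 1, for which the difference is a 1.1-fold lower number from compound 1 to compound 2 (0.06 log units; within the scatter).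

Compound 4 `C=C1CC(Cn2ccc(=O)[nH]c2=O)(c2ccc(F)cc2)OC1=O` differs from compound 2 by hydrogen in place of methyl on an aromatic carbon. Going by the values given here, the one measured step that bears on this change is the same swap made on compound 1, which gave a 1.3-fold lower number from compound 1 to compound 3 (0.12 log units; within the scatter). On that basis no step beyond the scatter is expected in this assay; the estimated change is a 1.2-fold lower number from compound 2 to compound 4 (0.08 log units; within the scatter). Compound 4 is therefore expected to give about 9500 nM, with a likely range from 4500 nM to 20000 nM.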

Compound 4, concentration for 50% growth inhibition: 15500 nM
For compound 4 the middle estimate is 1.6-fold (0.21 log units) below the measured one, and the stated range covers the measured number.
By their numbers in this assay, from the lowest: compounds 3, 2, 1 and 4 (each within the scatter of the next).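

In this assay, hydrogen in place of methyl at this ring carbon gives a 1.3-fold higher number from compound 2 to compound 4 (0.13 log units; within the scatter), so the swap now stays within the scatter on a second core: the same change on two cores in this assay, a 1.3-fold lower number (0.12 log units; within the scatter) from compound 1 to compound 3 and a 1.3-fold higher number (0.13 log units; within the scatter) from compound 2 to compound 4, 1.8-fold (0.25 log units) apart, within the scatter of two such steps

Fluoro in place of phenyl, now read with hydrogen at that ring carbon, gives a 1.6-fold higher number from compound 3 to compound 4 (0.19 log units; within the scatter), also within the scatter: the same change on two cores in this assay, a 1.1-fold lower number (0.06 log units; within the scatter) from compound 1 to compound 2 and a 1.6-fold higher number (0.19 log units; within the scatter) from compound 3 to compound 4, 1.8-fold (0.25 log units) apart, within the scatter of two such steps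

Neither change can therefore be told from the scatter on either core.

From the compounds shown here alone, it remains open whether an amine, a carboxylic acid or a longer chain at this ring carbon would move the number beyond the scatter.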